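The source may hold more compounds than are shown below. What is called first, only, known or untested is meant among the compounds shown, and "the series" means these compounds.

In an ADME assay on HepG2 cells (Homo sapiens) for cytotoxicity (a higher number here means that more compound is needed for the effect, a lower number that less compound is needed), compound 1 (`Cc1ccc(S(=O)(=O)N[C@@H](CC(=O)NC(C)(C)C)C(=O)NCCNC(=O)Nc2ccccc2)cc1`) gives > 11000 nM as a limit of the assay, not a number. Compound 2 (`COc1cccc(C(=O)NCCNC(=O)[C@H](CC(=O)NC(C)(C)C)NS(=O)(=O)c2ccc(C)cc2)c1`) gives > 11000 nM as a limit too. Compound 3 (`Cc1ccc(S(=O)(=O)N[C@@H](CC(=O)NC(C)(C)C)C(=O)NCCNC(=O)c2cccc(C#N)c2)cc1`) also gives > 11000 nM as a limit. Compound 3 therefore has no number of its own, and its place is the one shared by all three compounds (the limit of > 11000 nM in this assay, at which 3 of the 3 values shown sit).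

Compound 4 (`Cc1ccc(S(=O)(=O)N[C@@H](CC(=O)NC(C)(C)C)C(=O)NCCNS(=O)(=O)c2ccccc2)cc1`) has not yet been measured. It carries phenylsulfonyl in place of (3-cyanophenyl)carbonyl on an amine nitrogen. Among the compounds with values here, three measured steps bear on this change: a step that the two limits leave unreadable from compound 1 to compound 2 and a step that the two limits leave unreadable from compound 1 to compound 3 and a step that the two limits leave unreadable from compound 2 to compound 3 all alter the group on that same nitrogen. None of them has a readable size, and none of them brings in a sulfonyl group, so they offer only a weak guide.

With nothing readable to go on, no shift beyond the scatter is expected in this assay and no direction can be claimed. The estimated change is a step that the limit leaves unreadable from compound 3 to compound 4 in size, and another limit is the likeliest report. For compound 4 the estimate is 18000 nM as the expected value, with an expected range from 8000 nM to 40000 nM around it.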

Compound 4, half-maximal effective concentration: > 11000 nM
Compound 4 was reported as a limit (the forecaster's own chance of this, stated with the estimate: 85%); the middle value does not contradict the limit.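

Compound 4 also gives a limit of the assay in this assay rather than a number, so its steps from compound 1, compound 2 and compound 3 cannot be read. All four compounds share one place: the limit of > 11000 nM in this assay, at which 4 of the 4 values shown sit.

The compounds shown leave open how much of each is needed for the effect, and whether changing the group on that amine nitrogen alters it at all.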